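This account rests on a few compounds, and the source may have more. Where it says the series, first, only, none or still open, it means among the compounds named here.

Measured compounds:

- compound 1, `Cc1cc(NC(=O)Cn2cc(-c3ccc(Cl)cc3)nn2)no1`: 1910 nM
- compound 2, `COc1ccc(-c2cn(CC(=O)Nc3nccs3)nn2)cc1`: 510 nM
- compound 3, `Cc1cc(NC(=O)Cn2cc(-c3ccc(C#N)cc3)nn2)no1`: 9320 nM

All three were tested in a functional assay on BMDM cells (Mus musculus, strain C57BL/6) for inhibition, with a stated time of 2 days; a lower number here means a stronger inhibitor, a higher number a weaker inhibitor. Among them compound 3 gives the highest number, 9320 nM; its nearest neighbour is compound 1, which shares the same core and differs only in the group on the outer aromatic ring. For the measured compounds named here, that one measured step, a 4.9-fold higher number from compound 1 to compound 3 (0.69 log units; beyond the scatter), is the only direct comparison of substituents on this core.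

Compound 4, `COc1ccc(-c2cn(CC(=O)Nc3cc(C)on3)nn2)cc1`, has not yet been tested. It differs from compound 3 in one place: methoxy in place of cyano on an aromatic carbon. Going by the values given here, no measured pair shows methoxy in place of cyano on the same core, so the step can only be judged indirectly. The step from compound 1 to compound 3 shows that cyano was the weaker choice at this position. Compound 2 carries a methoxy on its outer ring, though on a different amide core, and gives 510 nM, the lowest number of the three. Taken together, these suggest that moving away from cyano should lower the number again, and the estimated step of a 7.2-fold lower number from compound 3 to compound 4 (0.86 log units; beyond the scatter) reflects that expectation. Compound 4 is therefore estimated at 1300 nM, within a range of 400 nM to 4500 nM.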

Compound 4, half-maximal inhibitory concentration: > 30000 nM
Compound 4: only a limit was reported; the forecaster's own chance of this, stated with the estimate: 5%; middle value at least 23-fold (1.36 log units) from the limit.
By their numbers in this assay, from the lowest: compound 2; then compound 1; then compound 3. At a limit, above all of these: compound 4.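

In this assay compound 4 gave only a limit, not a number: the limit of > 30000 nM in this assay, at which 1 of the 4 values shown sits. Swapping cyano for methoxy on this core therefore raises the number rather than lowering it, with an at least 3.2-fold higher number from compound 3 to compound 4 (0.50 log units; beyond the scatter), and the gap to the chloro compound is wider still, with an at least 15-fold higher number from compound 1 to compound 4 (1.19 log units; beyond the scatter). Methoxy at this position is thus not favourable in itself: with methoxy held fixed, the step with 5-methyl-1,2-oxazol-3-yl in place of 1,3-thiazol-2-yl on the amide-type nitrogen is an at least 58-fold higher number from compound 2 to compound 4 (1.76 log units; beyond the scatter), which shows that the outcome of a change at this position can depend on the group carried on that nitrogen.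

The exact number for compound 4 remains unknown, so the true size of all three steps is open, and the compounds shown do not say whether chloro or cyano would behave differently alongside 1,3-thiazol-2-yl. Nor do they show how an amine or a hydroxyl group on the same aromatic carbon, para to a large group, would compare on either amide.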